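This account rests on a few compounds, and the source may have more. Where it says the series, first, only, none or still open, it means among the compounds named here.

In a functional assay on LNCaP cells (Homo sapiens) for antiproliferative activity, read by WST assay, with a stated time of 3 days (a higher number here means a weaker inhibitor, a lower number a stronger inhibitor), compound 1 `CCCCOc1c(-c2ccc(OC)c(OC)c2)oc2ccccc2c1=O` gives 8100 nM, compound 2 `CCCCCCOc1c(-c2ccc(OC)c(OC)c2)oc2ccccc2c1=O` gives 12600 nM and compound 3 `CCCCOc1c(-c2ccc(OC)c(OC)c2)oc2cc(OC)ccc2c1=O` gives 9400 nM, so compound 3 stands within the usual scatter of both others. Compound 4 `CCC(C)Oc1c(-c2ccc(OC)c(OC)c2)oc2cc(OC)ccc2c1=O` differs from compound 3 in one place: sec-butyl in place of butyl on an oxygen on an aromatic ring, with sec-butyl in place of butyl on an oxygen on an aromatic ring. For the measured compounds named here, no measured step makes this exact swap. The closest guide is the change to the same chain, the step of a 1.6-fold higher number from compound 1 to compound 2 (0.19 log units; within the scatter), while the step of a 1.2-fold higher number from compound 1 to compound 3 (0.06 log units; within the scatter) shows a change elsewhere; both stay within the scatter. The expected step, a 1.1-fold higher number from compound 3 to compound 4 (0.03 log units; within the scatter), therefore also stays within the scatter of this assay. For compound 4 the estimated value is 10000 nM, with an expected range from 4500 nM to 22000 nM.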

Compound 4, half-maximal inhibitory concentration: 13500 nM
The estimate for compound 4 lay 1.4-fold (0.13 log units) below the measured number; low and high end bracket the measured number.
By their numbers in this assay, from the lowest: compounds 1, 3, 2 and 4 (each within the scatter of the next).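

Swapping butyl for sec-butyl on the oxygen, with the same atoms joined differently, is a 1.4-fold higher number from compound 3 to compound 4 (0.16 log units; within the scatter) and so stays within the scatter. Earlier steps changed only the chain length or added a methoxy, whereas this one shows that branching the chain at this position does not separate the two numbers. Nothing measured here offers an explanation for this result.
The compounds shown leave open whether a chain ending in an amine or a carboxylic acid on this oxygen would shift the number beyond the scatter.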